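The source may hold more compounds than are shown below. What is called first, only, known or untested is meant among the compounds shown, and "the series" means these compounds.

Notes on the cytotoxicity series. Compound 1 `Cc1ccc(C(=O)Nc2cc(Cl)ccc2OCC(=O)Nc2ccc(S(N)(=O)=O)cc2C)cc1` gives 54200 nM in a functional assay on C8166 cells (Homo sapiens) for cytotoxicity, read by MTT assay (a lower number here means that less compound is tolerated, a higher number that more compound is tolerated), the second highest of the three numbers measured. Compound 2 `Cc1ccc(C(=O)Nc2cc(Cl)ccc2OCC(=O)Nc2ccc(S(N)(=O)=O)cc2C)cc1C` gives 84100 nM and compound 3 `Cc1cc(C)cc(C(=O)Nc2cc(Cl)ccc2OCC(=O)Nc2ccc(S(N)(=O)=O)cc2C)c1` gives 36500 nM; the step of a 1.6-fold higher number from compound 1 to compound 2 (0.19 log units; within the scatter) and the step of a 1.5-fold lower number from compound 1 to compound 3 (0.17 log units; within the scatter) both sit within the scatter, while a 2.3-fold lower number from compound 2 to compound 3 (0.36 log units; beyond the scatter) is modest.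

Compound 4 `Cc1cc(S(N)(=O)=O)ccc1NC(=O)COc1ccc(Cl)cc1NC(=O)c1cc(Br)cc(Br)c1` differs from compound 1 by 3,5-dibromophenyl in place of 4-methylphenyl on a carbonyl carbon. For the measured compounds named here, the step that bears most directly on it is a 1.5-fold lower number from compound 1 to compound 3 (0.17 log units; within the scatter), the only other exchange on the same carbonyl carbon, and it was small. On that basis a small downward step is expected in this assay, at most modest, since the nearest comparison, the step from compound 1 to compound 3, stayed within the scatter.

Compound 4 is therefore expected at 35000 nM, with a range of 12000 nM to 90000 nM, corresponding to the expected step of a 1.5-fold lower number from compound 1 to compound 4 (0.19 log units; within the scatter).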

Compound 4, half-maximal cytotoxic concentration: 89700 nM
Compound 4: middle estimate off by 2.6-fold (0.41 log units), on the low side; the measured number falls inside the stated range.
By their numbers in this assay, from the lowest: compounds 3, 1, 2 and 4 (each within the scatter of the next, the first and the last beyond it).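

On the carbonyl carbon in this assay, 3,5-dibromophenyl stays within the scatter of both 4-methylphenyl (a 1.7-fold higher number from compound 1 to compound 4 (0.22 log units; within the scatter)) and 3,4-dimethylphenyl (a 1.1-fold higher number from compound 2 to compound 4 (0.03 log units; within the scatter)). Against 3,5-dimethylphenyl the exchange is modest (a 2.5-fold higher number from compound 3 to compound 4 (0.39 log units; beyond the scatter)), so bromine in place of methyl on the 3,5-disubstituted phenyl gives a step beyond the scatter, which the earlier compounds did not show. No measurement on hand offers an explanation for this step. Still open, from the compounds shown here alone, is whether 3,5-dichlorophenyl, or a phenyl bearing an amine, would fall with compound 3 or with compound 4.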